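The compounds below may be only part of what the source reports. "The series", "measured", "known", "first", "only" and "open" are said of these compounds alone.

In an ADME assay on MT4 cells (Homo sapiens) for cytotoxicity, read by MTT assay, with a stated time of 96 h (a lower number here means that less compound is tolerated, a higher number that more compound is tolerated), compound 2 `CC(=O)c1ccc2c(c1)nc(-c1ccc(Cl)cc1)n2C1CCCCC1` gives 58000 nM and compound 3 `CC(=O)c1ccc2c(c1)nc(-c1ccoc1)n2C1CCCCC1` gives 63000 nM, so the two stand level within the scatter. For compound 1 `CC(=O)c1ccc2[nH]c(-c3ccccc3)nc2c1` the entry is "not determined" (no result reported). The next compound is compound 4 `CC(=O)c1ccc2[nH]c(-c3ccoc3)nc2c1`, which departs from compound 3 by hydrogen in place of cyclohexyl on an aromatic nitrogen. Among the measured compounds shown here, the only measured step, a 1.1-fold higher number from compound 2 to compound 3 (0.04 log units; within the scatter), is a change on an aromatic carbon, not on the nitrogen, and so bears on this change only loosely. Compound 1 also has hydrogen on that nitrogen but offers no number. No step beyond the scatter is therefore expected in this assay, with a slight lean towards a higher number. The expected step is a 1.4-fold higher number from compound 3 to compound 4 (0.15 log units; within the scatter). Compound 4 is estimated at 90000 nM, with an expected range of 35000 nM to 200000 nM.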

Compound 4, half-maximal cytotoxic concentration: > 100000 nM
Compound 4 was reported as a limit; the forecaster's own chance of this, stated with the estimate: 45%; middle value at least 1.1-fold (0.04 log units) from the limit.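

Hydrogen in place of cyclohexyl on the aromatic nitrogen gives an at least 1.5-fold higher number from compound 3 to compound 4 (0.20 log units; that floor lies within the scatter) in this assay, the first reading of a change at this position; compound 1 also carries hydrogen there, but without a result. The floor of this step lies within the scatter, so the loss of cyclohexyl is not shown to change the reading. Compound 4 stands as a limit, not a number: the limit of > 100000 nM in this assay, at which 1 of the 4 values shown sits. As far as these compounds go, the full size of the step remains open, as does the reading with an amine or a carboxylic acid on a longer chain at this nitrogen.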